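Sulfonyl sulfur substituent: from compound 2 to compound 3

A few compounds are considered here, and "the series" means these few. Any claim that something is new, unique, unknown or untested is made for them only; others in the source may bear on it.

Measured in a functional assay on HeLa cells (Homo sapiens) for cytotoxicity, read by sulforhodamine B assay; a lower number here means a stronger inhibitor, a higher number a weaker inhibitor:
- compound 1 `COc1ccc(S(=O)(=O)NC(C2=CC(=O)c3c(O)ccc(O)c3C2=O)C(C)C)c(OC)c1`: 2750 nM
- compound 2 `CC(C)C(NS(=O)(=O)c1cccc(Br)c1)C1=CC(=O)c2c(O)ccc(O)c2C1=O`: 860 nM

Compound 2 has the lower of the two values. Within the data shown here, the only measured step is a 3.2-fold lower number from compound 1 to compound 2 (0.50 log units; beyond the scatter), modest and beyond the scatter, at the same place on the sulfonyl sulfur. Next is compound 3 `CC(=O)c1ccc(S(=O)(=O)NC(C2=CC(=O)c3c(O)ccc(O)c3C2=O)C(C)C)cc1`, with 4-acetylphenyl in place of 3-bromophenyl on a sulfonyl sulfur. Among the measured compounds shown here, no measured compound carries 4-acetylphenyl, so that single step gives only a rough size. A modest move to a higher number is expected in this assay. The estimate means an expected 1.7-fold higher number from compound 2 to compound 3 (0.24 log units; within the scatter). For compound 3 the estimated value is 1500 nM, with an expected range of 600 nM to 3800 nM.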

Compound 3, half-maximal inhibitory concentration: 3820 nM
For compound 3 the middle estimate is 2.5-fold (0.41 log units) below the measured one; the whole stated range lies below it.
By their numbers in this assay, from the lowest: compound 2; then compounds 1 and 3 (each within the scatter of the next).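

In this assay, 4-acetylphenyl on the sulfonyl sulfur gives a 4.4-fold higher number from compound 2 to compound 3 (0.65 log units; beyond the scatter) and so does not match 3-bromophenyl, a modest step beyond the scatter. Against 2,4-dimethoxyphenyl it gives a 1.4-fold higher number from compound 1 to compound 3 (0.14 log units; within the scatter) within the scatter, leaving 3-bromophenyl alone at the low end among these three groups. No measurement offered here explains this difference. Still open, going by these compounds, is whether the lower number of compound 2 belongs to the bromine itself. Also open, on these data alone, is how a plain phenyl, a phenyl carrying an amine or carboxylic acid, or a methyl on the sulfonyl sulfur would compare.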